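From 3-fluorophenyl to 4-fluorophenyl on a shared core

This account rests on a few compounds, and the source may have more. Where it says the series, first, only, none or still open, it means among the compounds named here.

Measured so far in a functional assay on HepG2 cells (Homo sapiens) for antiproliferative activity, read by MTT assay, with a stated time of 48 h; on this read-out lower numbers stand for stronger inhibition and higher numbers for weaker inhibition
Compound 1 `CC(=O)N1N=C(c2ccc3ccccc3c2)OC1c1ccccc1Br` gives 3.98 ug/mL
Compound 2 `CC(=O)N1N=C(c2ccc3ccccc3c2)OC1c1cccc(F)c1` gives 1.86 ug/mL

Within the data shown here, of these two, compound 2 has the lower number, and compound 1 is its only neighbour. Compound 3 `CC(=O)N1N=C(c2ccc3ccccc3c2)OC1c1ccc(F)cc1` has not yet been measured. It carries 4-fluorophenyl in place of the 3-fluorophenyl of compound 2 on a saturated ring carbon (4-fluorophenyl in place of 3-fluorophenyl on a saturated ring carbon), so the two have the same atoms, joined differently.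

Among the measured compounds shown here, only one measured step bears on this change: a 2.1-fold lower number from compound 1 to compound 2 (0.33 log units; beyond the scatter), which is modest but beyond the scatter. For the measured compounds named here, that step swapped 2-bromophenyl for 3-fluorophenyl, so it exchanged the halogen as well, and no measured pair isolates a shift of the fluorine alone. Given that this larger exchange produced only a modest step, little movement is expected here, and probably none beyond the scatter in this assay. The estimated change is a 1.1-fold higher number from compound 2 to compound 3 (0.05 log units; within the scatter). Compound 3 is expected at 2.1 ug/mL (estimated range 1 ug/mL to 4.5 ug/mL).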

Compound 3, half-maximal inhibitory concentration: 1.82 ug/mL
For compound 3 the middle estimate is 1.2-fold (0.06 log units) above the measured one, within the range that was stated.
By their numbers in this assay, from the lowest: compounds 3 and 2 (each within the scatter of the next); then compound 1.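

In this assay the fluorine on the phenyl group at the saturated ring carbon has now been moved on its own, something the earlier pair could not show: 4-fluorophenyl in place of 3-fluorophenyl gives a 1.0-fold lower number from compound 2 to compound 3 (0.01 log units; within the scatter) and so this shift leaves the reading within the scatter. Measured against 2-bromophenyl, the new compound gives a 2.2-fold lower number from compound 1 to compound 3 (0.34 log units; beyond the scatter) which matches in size the earlier 2.1-fold lower number from compound 1 to compound 2 (0.33 log units; beyond the scatter) and means the gap from compound 1 no longer rests on a single fluorophenyl compound. No evidence is available to explain why the two fluorophenyl compounds read alike or why compound 1 stands apart from them.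

The compounds shown do not separate the effect of the halogen from the effect of its place on the ring, as the steps from compound 1 change both at once. Also open, on these data alone, is whether this position tolerates only halogens or other groups too, such as an amine, a carboxylic acid or a plain unsubstituted phenyl, since every compound here carries a halogen on that ring.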